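Working notes: from compound 1 to compound 4

The compounds below may be only part of what the source reports. "The series", "measured", "known", "first", "only" and "open" are said of these compounds alone.

Measured in a functional assay with Mus musculus as the target; on this read-out lower numbers stand for an effect already at smaller amounts and higher numbers for an effect only at larger amounts of compound:
- compound 1 `Nc1nc(O)c2c(n1)n(C1OC(CO)[C@@H](O)[C@H]1O)c(=O)n2C/C=C/c1ccccc1`: 4 uM
- compound 2 `CCCn1c(=O)n(C2OC(COP(=O)(O)O)[C@@H](O)[C@H]2O)c2nc(N)nc(O)c21`: 82 uM
- compound 3 `CCCn1c(=O)n(C2CCC(COC(C)=O)O2)c2nc(NC(C)=O)nc(O)c21`: 80 uM

Compound 1 holds the lowest number of the three, clearly apart from compound 2 and compound 3, which lie within the scatter of each other. Compound 4 `COc1ccc(Cn2c(=O)n(C3OC(CO)[C@@H](O)[C@H]3O)c3nc(N)nc(O)c32)cc1` is still unmeasured. It differs from compound 1 as follows: 4-methoxyphenyl in place of 2-phenylethenyl on a saturated chain carbon bound to an aromatic nitrogen. That is 4-methoxyphenyl in place of 2-phenylethenyl on a saturated chain carbon bound to an aromatic nitrogen. Among the compounds with values here, no measured pair differs in one place only, so direct evidence for this change is lacking. A modest step to a higher number in this assay is expected, little beyond the scatter, since compound 1 at 4 uM is the lowest so far. The expected step is a 2.5-fold higher number from compound 1 to compound 4 (0.40 log units; beyond the scatter). For compound 4 the estimated value is 10 uM, with an expected range of 3 uM to 40 uM.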

Compound 4, concentration for half-maximal effect: 2 uM
Beside the measured number, compound 4's estimate is 5.0-fold (0.70 log units) above it; measured number outside the range, below it.
By their numbers in this assay, from the lowest: compounds 4 and 1 (each within the scatter of the next); then compounds 3 and 2 (each within the scatter of the next).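

In this assay, the position on a saturated chain carbon bound to an aromatic nitrogen accepts 4-methoxyphenyl in place of 2-phenylethenyl, with a 2.0-fold lower number from compound 1 to compound 4 (0.30 log units; within the scatter) as the step. The double bond outside aromatic rings is therefore not required here for a number in this low range, and an added hydrogen-bond acceptor on the group does not separate the two compounds beyond the scatter. No evidence bears on why the two groups read alike.

Open, as far as these compounds go, is how an amine, a carboxylic acid or a longer alkyl chain in place of 4-methoxyphenyl would read in this assay at this position.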